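This account rests on a few compounds, and the source may have more. Where it says the series, first, only, none or still open, it means among the compounds named here.

Three compounds have been measured so far in an ADME assay on CCRF-CEM cells (Homo sapiens) for antiproliferative activity, with a stated time of 48 h (a lower number here means a stronger inhibitor, a higher number a weaker inhibitor), and they read as follows

Compound 1 `C=C(Br)C(=O)Nc1ccc(/C=C/C(=O)c2ccc(Cl)cc2)cc1` gives 950 nM
Compound 2 `C=C(Br)C(=O)Nc1ccc(/C=C/C(=O)c2ccc(Cl)c(Cl)c2)cc1` gives 1700 nM
Compound 3 `C=C(Br)C(=O)Nc1ccc(/C=C/C(=O)c2ccc(Br)cc2)cc1` gives 990 nM

Compound 2 cannot be told apart from the other two on these numbers. The measurements show a 1.8-fold higher number from compound 1 to compound 2 (0.25 log units; within the scatter) and also a 1.7-fold lower number from compound 2 to compound 3 (0.23 log units; within the scatter) as the two steps that reach it.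

The change to be followed leads to compound 4 `C=C(Br)C(=O)Nc1ccc(/C=C/C(=O)c2ccc(OC)cc2)cc1` and is counted as 4-methoxyphenyl in place of 3,4-dichlorophenyl on a carbonyl carbon with 4-methoxyphenyl in place of 3,4-dichlorophenyl on a carbonyl carbon. For the measured compounds named here, no measured compound carries 4-methoxyphenyl, so the data give no direct guide to this group. The nearest evidence comes from the changes already made in this part of the molecule. Besides the two steps above there is a 1.0-fold higher number from compound 1 to compound 3 (0.02 log units; within the scatter) and all three stay within the scatter. With compound 1 at 950 nM and compound 3 at 990 nM as the reference points, no change beyond the scatter is expected in this assay although this evidence covers only chloro and bromo groups. The expected step is a 1.7-fold lower number from compound 2 to compound 4 (0.23 log units; within the scatter) and it remains an expectation until measured. For compound 4 the estimated value is 1000 nM with an expected range from 300 nM to 2500 nM in this estimate.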

Compound 4, half-maximal inhibitory concentration: 1400 nM
Compound 4: the middle estimate sits 1.4-fold (0.15 log units) below what was measured; low and high end bracket the measured number.
By their numbers in this assay, from the lowest: compounds 1, 3, 4 and 2 (each within the scatter of the next).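

In this assay, for the compounds shown here, the aromatic ring on the carbonyl carbon had so far carried only chloro and bromo, and 4-methoxyphenyl is the first group here to bring oxygen to that ring instead of a halogen, with a 1.2-fold lower number from compound 2 to compound 4 (0.08 log units; within the scatter) and a 1.4-fold higher number from compound 3 to compound 4 (0.15 log units; within the scatter) and also a 1.5-fold higher number from compound 1 to compound 4 (0.17 log units; within the scatter) as the steps that reach compound 4. All three steps stay within the scatter, so this position accepts a methoxy group as well as the halogens without any readable shift in the number, and the earlier halogen-only compounds could not show this. No measurement offered here speaks to why the number holds when halogen gives way to methoxy.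

As far as these compounds go, it remains open whether an amine, a carboxylic acid or a longer chain such as ethoxy on this ring would also stay within the scatter or would finally separate from these four compounds. All four share everything outside this ring, so they say nothing about how a change elsewhere in the core of compound 1, such as at the amide hydrogen, would read.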